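A few compounds are considered here, and "the series" means these few. Any claim that something is new, unique, unknown or untested is made for them only; others in the source may bear on it.

In a functional assay on DLD-1 cells (Homo sapiens) for antiproliferative activity, read by CellTiter-Glo, with a stated time of 72 h (a lower number here means a stronger inhibitor, a higher number a weaker inhibitor), compound 1 `Cc1cc(C)c(S(=O)(=O)N2CCC(N3CCC(C)CC3)CC2)c(C)c1` gives 0.03 nM, the lowest number among the compounds measured. Compound 3 `Cc1cc(C)c(S(=O)(=O)N2CCC(N3CCN(C)CC3)CC2)c(C)c1` gives 1100 nM. Compound 2 `Cc1cc(C)c(S(=O)(=O)N2CCC(c3ccccc3)CC2)c(C)c1` returns only a limit of the assay, > 5000 nM.

Compound 4 `Cc1cc(C)c(S(=O)(=O)N2CCC(N3CCC(Cc4ccccc4F)CC3)CC2)c(C)c1` has not yet been measured. It differs from compound 1 by one change, 2-fluorophenyl in place of hydrogen on a saturated chain carbon bound to a saturated ring carbon, which also reads as methyl to 2-fluorobenzyl.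

Going by the values given here, no measured step makes this exact change. The nearest evidence comes from replacing the whole 4-methylpiperidin-1-yl group. Phenyl in its place gives an at least 160000-fold higher number from compound 1 to compound 2 (5.22 log units; beyond the scatter), and 4-methylpiperazin-1-yl in its place gives a 37000-fold higher number from compound 1 to compound 3 (4.56 log units; beyond the scatter). Both steps are large and both raise the number, so this assay responds steeply to changes in this part of compound 1. The step of an at least 4.5-fold lower number from compound 2 to compound 3 (0.65 log units; beyond the scatter) is much smaller. Compound 4 keeps more of that group than compound 2 or compound 3 does, so a rise is expected, but a smaller one than those two large steps. The expected size is a 67-fold higher number from compound 1 to compound 4 (1.82 log units; beyond the scatter), and it remains uncertain. Compound 4 is estimated at 2 nM, with an expected range from 0.05 nM to 200 nM.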

Compound 4, half-maximal inhibitory concentration: 74 nM
For compound 4 the middle estimate is 37-fold (1.57 log units) below the measured one, and the stated range covers the measured number.
By their numbers in this assay, from the lowest: compound 1; then compound 4; then compound 3. At a limit, above all of these: compound 2.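

The earlier steps shown here replaced the whole 4-methylpiperidin-1-yl group, so they could not show whether the outer methyl matters on its own. Compound 4 keeps that group's ring and changes only methyl to 2-fluorobenzyl, and in this assay this single change gives a 2500-fold higher number from compound 1 to compound 4 (3.39 log units; beyond the scatter). The number is therefore highly sensitive to this saturated chain carbon alone, although this step is smaller than a 37000-fold higher number from compound 1 to compound 3 (4.56 log units; beyond the scatter), and compound 2 remains a limit of the assay rather than a number: the limit of > 5000 nM in this assay, at which 1 of the 4 values shown sits.

The compounds shown leave open how much of the rise belongs to the fluorine, how much to the aromatic ring and how much to the sheer size of the new group, since nothing here separates 2-fluorobenzyl from a plain benzyl, an ethyl or a longer alkyl chain. They also leave open whether a different kind of group at this place, such as a hydroxyl, an amine or a carboxylic acid, would hold the number nearer to that of compound 1.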